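Swapping the aryl group on a weakly cytotoxic compound

The compounds below may be only part of what the source reports. "The series", "measured", "known", "first", "only" and "open" are said of these compounds alone.

Compound 1 `CC1=C(CC(=O)NCCN(C)C)c2cc(F)ccc2/C1=C\c1nc2ccccc2s1`: 1570 nM
Compound 2 `CC1=C(CC(=O)N2CCN(CCCN(C)C)CC2)c2cc(F)ccc2/C1=C\c1ccc([S+](C)[O-])cc1`: 23800 nM
Compound 3 `CC1=C(CC(=O)N2CCN(c3ccncc3)CC2)c2cc(F)ccc2/C1=C\c1ccc([S+](C)[O-])cc1`: 9200 nM

In a functional assay on HT-29 cells (Homo sapiens) for inhibition, read by CellTiter-Glo, with a stated time of 72 h (a lower number here means that less compound is tolerated, a higher number that more compound is tolerated), compound 2 gives 23800 nM, the highest of the three numbers, so it is the most tolerated of these compounds. The next compound, compound 4 `CC1=C(CC(=O)N2CCN(CCCN(C)C)CC2)c2cc(F)ccc2/C1=C\c1nc2ccccc2s1`, keeps the amide side of compound 2 and changes the other end: a group of 9 heavy atoms (7 carbon, 1 nitrogen, 1 sulfur; one five-membered aromatic ring with 2 hetero atoms, one six-membered aromatic ring of carbon only) in place of a group of 9 heavy atoms (7 carbon, 1 oxygen, 1 sulfur; one six-membered aromatic ring of carbon only), on a double-bonded chain carbon bound to a double-bonded ring carbon.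

For the measured compounds named here, the one measured step, a 2.6-fold lower number from compound 2 to compound 3 (0.41 log units; beyond the scatter), changes a group on a ring amine nitrogen, not this site, so it offers only a rough sense of how large a single change can be. The better clue is compound 1, which carries the same 1,3-benzothiazol-2-yl group as compound 4, and compound 1 gives 1570 nM. Compound 1 differs from compound 4 on the amide side too, so it is only a partial guide.

A move to a lower number is therefore expected, and the expected size is a 6.0-fold lower number from compound 2 to compound 4 (0.77 log units; beyond the scatter). For compound 4 the estimated value is 4000 nM, with an expected range from 1200 nM to 14000 nM.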

Compound 4, half-maximal cytotoxic concentration: 1620 nM
Estimate against measurement, compound 4: 2.5-fold (0.39 log units) above; the measured number falls inside the stated range.
By their numbers in this assay, from the lowest: compounds 1 and 4 (each within the scatter of the next); then compound 3; then compound 2.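

In this assay, for the compounds shown here, placing 1,3-benzothiazol-2-yl on the double-bonded chain carbon gives a 15-fold lower number from compound 2 to compound 4 (1.17 log units; beyond the scatter), so this site can carry a larger change than the ring amine nitrogen, where the one earlier step was a 2.6-fold lower number from compound 2 to compound 3 (0.41 log units; beyond the scatter). With 1,3-benzothiazol-2-yl held constant, 4-(3-(dimethylamino)propyl)piperazin-1-yl in place of (2-(dimethylamino)ethyl)amino on the carbonyl carbon gives a 1.0-fold higher number from compound 1 to compound 4 (0.01 log units; within the scatter). This pair therefore shows no measurable difference between these two amide sides, which also makes compound 1 a closer guide to compound 4 than it could be shown to be beforehand.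

No measurement shown here explains why the aryl swap has so large an effect. Going by these compounds, it also remains open whether the same shift would appear with the pyridin-4-yl amide side of compound 3, or with a 1,3-benzoxazol-2-yl group, which has oxygen in place of the ring sulfur.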